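The source may hold more compounds than are shown below. What is called first, only, known or untested is meant among the compounds shown, and "the series" means these compounds.

Compounds measured so far:
- compound 1, `O=C(/C=C/c1ccccc1)NS(=O)(=O)c1ccc(Cl)cc1`: 2.2 ug/mL
- compound 2, `O=C(/C=C/c1ccc(Br)cc1)NS(=O)(=O)c1ccccc1`: 3.9 ug/mL

Both were tested in a functional assay on B16-F10 cells (Mus musculus) for antiproliferative activity, read by ELISA and MTT assay, with a stated time of 48 h; a lower number here means a stronger inhibitor, a higher number a weaker inhibitor. Compound 2 holds the higher of the two numbers, yet its gap to compound 1 lies within the usual scatter, so the two cannot be told apart. Compound 3, `O=C(/C=C/c1ccc(Br)cc1)NS(=O)(=O)c1ccc(Cl)cc1`, has not been measured yet. It differs from compound 2 by chloro in place of hydrogen on an aromatic carbon. Going by the values given here, no measured pair shows this exact change, so its size is open. Compound 1, which already carries this chloro, gives 2.2 ug/mL, so a step of a 1.6-fold lower number from compound 2 to compound 3 (0.19 log units; within the scatter) is expected for compound 3. In this assay the value of compound 3 is estimated at 2.5 ug/mL, between 1 ug/mL and 6 ug/mL.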

Compound 3, half-maximal inhibitory concentration: 5.2 ug/mL
Beside the measured number, compound 3's estimate is 2.1-fold (0.32 log units) below it; low and high end bracket the measured number.
By their numbers in this assay, from the lowest: compounds 1, 2 and 3 (each within the scatter of the next, the first and the last beyond it).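

In this assay, the change from phenyl to 4-chlorophenyl gives a 1.3-fold higher number from compound 2 to compound 3 (0.12 log units; within the scatter) when bromo is already present, so chloro has no readable effect in that setting. Bromo in place of hydrogen gives a 2.4-fold higher number from compound 1 to compound 3 (0.37 log units; beyond the scatter) and is the one modest change seen here, showing a weaker inhibitor when chloro is already present. Nothing available explains this step.

On these data alone, whether an amine or a carboxylic acid in place of either halogen would shift the number remains open. So does whether the bromo step holds with no chloro present.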